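This account rests on a few compounds, and the source may have more. Where it says the series, first, only, none or still open, it means among the compounds named here.

Working notes on the series.

Within the data shown here, compound 2 `COc1ccc2nc(C)cc(OCC(=O)Nc3ccc(F)cc3)c2c1` stands apart in the values shown so far: in a toxicity assay on HepG2 cells (Homo sapiens) for inhibition, read by CellTiter-Glo, with a stated time of 48 h (a higher number here means a weaker inhibitor, a lower number a stronger inhibitor), compound 2 gives 63100 nM, and this is the only outright number among the three results. Compound 1 `COc1ccc(NC(=O)COc2cc(C)nc3ccc(OC)cc23)cc1` is reported only as a limit of the assay, > 100000 nM. Compound 3 `COc1ccc2nc(C)cc(OCC(=O)Nc3cc(C)nc(C)n3)c2c1` likewise reaches only a limit, > 100000 nM. The readable steps are therefore thin: an at least 1.5-fold lower number from compound 1 to compound 2 (0.19 log units; that floor lies within the scatter), and an at least 1.5-fold higher number from compound 2 to compound 3 (0.19 log units; that floor lies within the scatter); the step that the two limits leave unreadable from compound 1 to compound 3 cannot be sized. The picture is shaped by the limit of > 100000 nM in this assay, at which 2 of the 3 values shown sit.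

Compound 4 `COc1ccc2nc(C)cc(OCC(=O)Nc3ccc(S(=O)(=O)Nc4cc(C)on4)cc3)c2c1` differs from compound 2 at one place: (5-methyl-1,2-oxazol-3-yl)sulfamoyl in place of fluoro on an aromatic carbon. Among the measured compounds shown here, no measured step touches this kind of change. For the measured compounds named here, the only step at the same position on the ring, from compound 1 to compound 2, swaps fluoro for methoxy and its floor lies within the scatter; the pyrimidinyl swaps concern the amide nitrogen instead. Nothing shown therefore supports an expectation of a step beyond the scatter in this assay in either direction, while two of three results being limits makes a further limit quite possible.

Compound 4 is accordingly estimated at 70000 nM, with a range from 25000 nM to 200000 nM. The step this estimate implies, a 1.1-fold higher number from compound 2 to compound 4 (0.05 log units; within the scatter), is expected to stay within the scatter.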

Compound 4, half-maximal inhibitory concentration: > 100000 nM
Compound 4 ended at the assay's limit (the forecaster's own chance of this, stated with the estimate: 50%); middle value at least 1.4-fold (0.15 log units) away from the limit.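

Placing (5-methyl-1,2-oxazol-3-yl)sulfamoyl in place of fluoro on this aromatic carbon gives an at least 1.5-fold higher number from compound 2 to compound 4 (0.19 log units; that floor lies within the scatter), the first step at this position that tests a group much larger than a single atom. Compound 4 is reported only as a limit of the assay, > 100000 nM, so this group of 10 heavy atoms with its five-membered aromatic ring yields no outright number in this assay, whereas fluoro at the same place does. The step between compound 1 and compound 4 cannot be read, and anything said about this position is capped by the top of the assay's range: the limit of > 100000 nM in this assay, at which 3 of the 4 values shown sit.

On these data alone, whether a plain sulfamoyl group without the five-membered ring, an amine or a carboxylic acid at this place would shift the number beyond the scatter stays open. Among these compounds, with only one outright value, it also stays open whether any change at this position can give a number well clear of the limit in this assay.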